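Chain homologation at the acid terminus

The source may hold more compounds than are shown below. What is called first, only, known or untested is meant among the compounds shown, and "the series" means these compounds.

Compound 1 `O=C(O)CC[C@@H]1CC[C@@H]2[C@@H](/C=C/[C@@H](O)COc3ccccc3)[C@H](O)C[C@@H]2OC1` and compound 2 `O=C(O)CCC[C@@H]1CC[C@@H]2[C@@H](/C=C/[C@@H](O)COc3ccccc3)[C@H](O)C[C@@H]2OC1` share one core and differ only in the length of the acid-bearing chain. In an ADME assay on CHO cells for agonist activity at prostacyclin receptor (Homo sapiens), read by HTRF and cAMP accumulation (a higher number here means that more compound is needed for the effect, a lower number that less compound is needed), compound 1 gives a limit of the assay, > 10000 nM. Compound 2 also gives a limit in this assay, > 10000 nM. The step that the two limits leave unreadable from compound 1 to compound 2 cannot be read, since the limit of > 10000 nM in this assay, at which 2 of the 2 values shown sit, holds both values. Compound 3 `O=C(O)CCCC[C@@H]1CC[C@@H]2[C@@H](/C=C/[C@@H](O)COc3ccccc3)[C@H](O)C[C@@H]2OC1` is the next homologue, the change being (carboxymethyl in place of carboxy on a saturated chain carbon, three bonds along the chain from a saturated ring carbon). No readable step bears on it, so no direction is set. Compound 3 is expected at 15000 nM, range 3000 nM to 60000 nM, a step that the limit leaves unreadable from compound 2 to compound 3, most likely again only a limit.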

Compound 3, half-maximal effective concentration: > 10000 nM
Compound 3: only a limit was reported; the forecaster's own chance of this, stated with the estimate: 85%; the middle value is on the limit's open side.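

Compound 3 also gives only a limit in this assay, so no step among compound 1, compound 2 and compound 3 can be read: the limit of > 10000 nM in this assay, at which 3 of the 3 values shown sit.

The compounds shown leave open whether any acid-bearing chain length on the shared core gives a measurable value.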